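Nitro position on the aryloxy group in compound 4

The compounds below may be only part of what the source reports. "The series", "measured", "known", "first", "only" and "open" are said of these compounds alone.

Compound 3 `CCOC(=O)c1cc(-c2ccc(OC)cc2)nn1CC(O)COc1ccc([N+](=O)[O-])cc1` gives 44000 nM in a functional assay on A549 cells (Homo sapiens) for inhibition, read by MTT assay, with a stated time of 48 h; on this read-out lower numbers stand for stronger inhibition and higher numbers for weaker inhibition. Compound 2 `CCOC(=O)c1cc(-c2ccc(OC)cc2)nn1CC(O)COc1ccc(Cl)cc1` gives 38000 nM and compound 1 `CCOC(=O)c1cc(-c2ccccc2)nn1CC(O)COc1ccccc1[N+](=O)[O-]` gives 30000 nM; both numbers lie within the scatter of compound 3, so no order among the three is established. Going by the values given here, the only measured single step, a 1.2-fold higher number from compound 2 to compound 3 (0.06 log units; within the scatter), concerns a different exchange on this aryl ring and lies within the scatter. Compound 4 `CCOC(=O)c1cc(-c2ccc(OC)cc2)nn1CC(O)COc1ccccc1[N+](=O)[O-]` differs from compound 3 by 2-nitrophenyl in place of 4-nitrophenyl on an oxygen on a saturated carbon. Among the compounds with values here, no measured step covers such a shift of the nitro group; compound 1 already carries 2-nitrophenyl, and its number sits within the scatter of compound 3. The expected step of a 1.2-fold lower number from compound 3 to compound 4 (0.09 log units; within the scatter) is therefore none beyond the scatter. Compound 4 is estimated at 36000 nM, with a range from 15000 nM to 85000 nM.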

Compound 4, half-maximal inhibitory concentration: 45000 nM
For compound 4 the middle estimate is 1.3-fold (0.10 log units) below the measured one, and the stated range covers the measured number.
By their numbers in this assay, from the lowest: compounds 1, 2, 3 and 4 (each within the scatter of the next).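

In this assay the shift of the nitro group gives a 1.0-fold higher number from compound 3 to compound 4 (0.01 log units; within the scatter), so 2-nitrophenyl in place of 4-nitrophenyl on this oxygen is now a measured exchange that separates nothing. The same holds for 2-nitrophenyl in place of 4-chlorophenyl (a 1.2-fold higher number from compound 2 to compound 4 (0.07 log units; within the scatter)) and for methoxy in place of hydrogen on an aromatic carbon (a 1.5-fold higher number from compound 1 to compound 4 (0.18 log units; within the scatter)), the first measured step away from the aryloxy group. No supporting data bear on these results.

Still open, going by these compounds, is whether an amine or a carboxylic acid on the aryloxy group, or an amide in place of the ethyl ester, would give a step beyond the scatter.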